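Methyl to Ethyl on Compound 2: An Expected Read-out

This account rests on a few compounds, and the source may have more. Where it says the series, first, only, none or still open, it means among the compounds named here.

Of the compounds shown here, three share one core and have been measured in an ADME assay on the whole organism with Oryza sativa as the target, tested at 0.1 uM; a higher number here means a weaker effect of the compound at the concentration tested, a lower number a stronger effect. Compound 1 `Cc1ccccc1NC(=O)N[C@H](C)c1ccccc1` gives 100%, compound 2 `Cc1ccc(NC(=O)N[C@H](C)c2ccccc2)cc1` gives 100%, and compound 3 `Cc1ccc(NC(=O)N[C@@H](C)c2ccccc2)cc1` gives 100%. For the measured compounds named here, the only single-point step among them is no change at the digits printed from compound 2 to compound 3 (within the scatter), and the two compounds behind that step differ only in drawn configuration, as the fact that compounds 2 and 3 differ only in the configuration as drawn records. Going by the values given here, compound 2 thus stands level with compounds 1 and 3 at the digits given, and no measured step so far moves the read-out beyond its scatter.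

Compound 4 `CCc1ccc(NC(=O)N[C@H](C)c2ccccc2)cc1` is not yet measured. It differs from compound 2 by methyl in place of hydrogen on a saturated chain carbon bound to an aromatic carbon. Among the compounds with values here, no measured step shares this change: the one step available, from compound 2 to compound 3, concerns a stereocentre and not the substituent on the aromatic ring, so it bears on compound 4 only in showing that the read-out has so far been flat at its upper edge. With nothing pointing either way, compound 4 is expected to sit close to compound 2, and the step of a number 2 percentage points lower from compound 2 to compound 4 (within the scatter) is estimated to lie within the scatter. Compound 4 is therefore estimated at 98%, with a range from 85% to 100%.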

Compound 4, a percentage reported as activity, at one concentration (the size of the read-out at that concentration, not a potency): 95%
Beside the measured number, compound 4's estimate is 3 percentage points above it; the range from low to high includes it.
By their numbers in this assay, from the lowest: compounds 4, 1, 2 and 3 (each within the scatter of the next).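

The step from methyl to ethyl, which places methyl in place of hydrogen on a saturated chain carbon bound to an aromatic carbon, gives a number 5 percentage points lower from compound 2 to compound 4 (within the scatter) in this assay. The earlier step concerned only drawn configuration, whereas this one alters the group itself, and it shows that the read-out can absorb this added methyl at this place without leaving the scatter, so a change of substituent here, like the change of configuration, has yet to produce a step beyond it. The facts at hand concern only configuration and say nothing on why this change of group leaves the read-out where it is.

On these data alone, whether a longer chain, an amine or a carboxylic acid at this same place would carry the read-out beyond the scatter stays open, since a single added methyl says little about larger or charged groups. Also open, as far as these compounds go, is whether ethyl behaves the same with the other drawn configuration at the stereocentre, and which change to the shared core, if any, would produce a clearly stronger effect at the concentration tested.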